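Pendant aryl swap to phenyl: cytotoxicity working notes

This account rests on a few compounds, and the source may have more. Where it says the series, first, only, none or still open, it means among the compounds named here.

Compound 1 `Cc1cc(-c2ccc3[nH]c(=O)nc(-c4ccccc4)c3c2)ccn1` gives > 50000 nM in an ADME assay on THP-1 cells (Homo sapiens) for cytotoxicity, read by MTT assay, with a stated time of 72 h (a lower number here means that less compound is needed, a higher number that more compound is needed for the effect), which is a limit of the assay and not a number. Compound 2 `Cc1ccncc1-c1ccc2[nH]c(=O)nc(-c3ccccc3)c2c1` carries 4-methylpyridin-3-yl in place of 2-methylpyridin-4-yl on an aromatic carbon. In this assay compound 2 gives > 50000 nM, again a limit rather than a number. The step that the two limits leave unreadable from compound 1 to compound 2 is therefore unreadable in size; both values sit at the limit of > 50000 nM in this assay, at which 2 of the 2 values shown sit. Compound 2 thus stands at the limit, with no number of its own on the scale.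

Compound 3 `O=c1nc(-c2ccccc2)c2cc(-c3ccccc3)ccc2[nH]1` differs from compound 2 by phenyl in place of 4-methylpyridin-3-yl on an aromatic carbon. Going by the values given here, the only measured step concerns the same pendant ring, and its size cannot be read. No shift beyond the scatter is expected, so compound 3 is expected to remain at the limit, with an estimated step of a number no higher from compound 2 to compound 3 (the limit leaves the size open). The estimate for compound 3 is 50000 nM, within 20000 nM to 100000 nM.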

Compound 3, half-maximal effective concentration: > 50000 nM
Compound 3 was reported as a limit (the forecaster's own chance of this, stated with the estimate: 85%); the middle value sits exactly at the limit.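

Going by these compounds alone, compound 1, compound 2 and compound 3 all stand at a limit, so no step among them can be read: the limit of > 50000 nM in this assay, at which 3 of the 3 values shown sit.

The compounds shown leave open whether, in this assay, any pendant ring on the shared core gives a number rather than a limit.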